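This account rests on a few compounds, and the source may have more. Where it says the series, first, only, none or still open, it means among the compounds named here.

Measured compounds in a functional assay on A-375 cells (Homo sapiens) for inhibition, read by sulforhodamine B assay, with a stated time of 48 h; on this read-out higher numbers stand for weaker inhibition of growth and lower numbers for stronger inhibition of growth:
compound 1 `COC(=O)c1sc2cc(-c3cccs3)cnc2c1N` gives > 150000 nM, a limit of the assay.
compound 2 `COC(=O)c1sc2cc(-c3ccc(-c4cccs4)s3)cnc2c1N` gives > 75000 nM, also a limit.
compound 3 `COC(=O)c1sc2cc(-c3cnc4ccccc4c3)cnc2c1N` gives 9100 nM.

Compound 1 stands only as a limit in this assay; no number places it against the other two. Going by the values given here, the single measured step that touches it, a step that the two limits leave unreadable from compound 1 to compound 2, cannot be read, since both of its ends are limits the limit of > 150000 nM in this assay, at which 1 of the 3 values shown sits (the limit of > 75000 nM in this assay, at which 1 of the 3 values shown sits). Compound 3, with its measured number, shows only that a different substituent at this place can yield a readable value. Compound 4 `COC(=O)c1sc2cc(-c3ccccc3N)cnc2c1N` carries 2-aminophenyl in place of thiophen-2-yl on an aromatic carbon. Among the compounds with values here, no measured step bears on this change, so its direction is open. Compound 4 is expected to give about 60000 nM, within 10000 nM to 150000 nM, and may again appear as a limit. That corresponds to an expected step of an at least 2.5-fold lower number from compound 1 to compound 4 (0.39 log units; beyond the scatter).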

Compound 4, concentration for 50% growth inhibition: 2500 nM
Compound 4: middle estimate off by 24-fold (1.38 log units), on the high side; measured number below the stated range.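

In this assay, 2-aminophenyl in place of thiophen-2-yl on this aromatic carbon gives a large, readable change, an at least 60-fold lower number from compound 1 to compound 4 (1.77 log units; beyond the scatter). This shows that the result at this position responds to the substituent, which the unreadable step between the two limits could not show. Compound 1 gives > 150000 nM, which is a limit, so the printed size is a minimum: the limit of > 150000 nM in this assay, at which 1 of the 4 values shown sits.

The compounds shown leave open whether the amine itself matters or the six-membered ring alone is enough. A plain phenyl group at this place, or a hydroxyl in place of the amine, would separate the two.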